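The source may hold more compounds than are shown below. What is called first, only, known or untested is meant among the compounds shown, and "the series" means these compounds.

Measured so far in an assay on CHO cells for displacement of a labelled ligand from Alpha-1B adrenergic receptor (Homo sapiens); on this read-out lower numbers stand for stronger inhibition and higher numbers for weaker inhibition:
- compound 2 `COc1cccc(C)c1OCCNCCOc1ccccc1OCc1ccccc1` gives 5.01 nM
- compound 1 `COc1cccc(Cl)c1OCCNCCOc1ccccc1OCc1ccccc1` gives 7.94 nM

Compound 2 has the lowest of the two numbers, with compound 1 nearest to it; the step of a 1.6-fold lower number from compound 1 to compound 2 (0.20 log units; within the scatter) lies within the scatter, so the two cannot be told apart on these data. Compound 3 `Cc1cccc(C)c1OCCNCCOc1ccccc1OCc1ccccc1` is not yet measured. It differs from compound 2 by methyl in place of methoxy on an aromatic carbon, so that the 2-methoxy-6-methylphenoxy part becomes a 2,6-dimethylphenoxy part while the rest of the shared core stays the same. Within the data shown here, the only measured step, from compound 1 to compound 2, swaps two small groups on the other aromatic carbon of this ring and stayed within the scatter, which suggests that small groups on this ring have little weight in this assay. Trading methoxy for methyl is a change of similar size, so no step beyond the scatter is expected in this assay, with at most a slight drift to a higher number. Compound 3 is therefore expected to give about 8 nM, between 3 nM and 20 nM, an expected step of a 1.6-fold higher number from compound 2 to compound 3 (0.20 log units; within the scatter).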

Compound 3, inhibition constant: 100 nM
For compound 3 the middle estimate is 13-fold (1.10 log units) below the measured one; measured number outside the range, above it.
By their numbers in this assay, from the lowest: compounds 2 and 1 (each within the scatter of the next); then compound 3.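

In this assay, this position on the ring turns out to be far less forgiving than the chloro-to-methyl swap suggested: that swap gave a 1.6-fold lower number from compound 1 to compound 2 (0.20 log units; within the scatter), while putting methyl in place of methoxy gives a 20-fold higher number from compound 2 to compound 3 (1.30 log units; beyond the scatter) and so a clearly weaker result. The same picture appears with the other methoxy compound, with a 13-fold higher number from compound 1 to compound 3 (1.10 log units; beyond the scatter), so among these three the two compounds that carry methoxy sit within the scatter of each other and compound 3, which lacks it, stands apart. Small groups of similar size are therefore not interchangeable on this ring, and nothing available here on the properties of these compounds accounts for the drop.

Still open, as far as these compounds go, is whether the loss comes from removing the oxygen or from the particular group that replaces methoxy, a question that a hydroxy or an ethoxy group at this place would help to answer. It is also unclear whether a 2-chloro-6-methylphenoxy part would behave like compound 3, which would show whether the effect depends on the group at the other position of the ring.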